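Moving the Chlorine from 3-Chlorobenzyl to 4-Chlorobenzyl

The source may hold more compounds than are shown below. What is called first, only, known or untested is meant among the compounds shown, and "the series" means these compounds.

Compound 1 `COc1ccc(C2N=C(SCc3cccc(Cl)c3)NC(C)=C2C(=O)Nc2ccc(Br)cc2)cc1` gives 26.8% in a functional assay on the whole organism (artery, strain albino) with Rattus norvegicus as the target, with a stated time of 720 min, at a dose of 10 mg/kg by the oral route; a higher number here means more inhibition at the dose given (going by the name of the read-out), a lower number less inhibition.
Compound 2 `COc1ccc(C2N=C(SCc3ccc(Cl)cc3)NC(C)=C2C(=O)Nc2ccc(Br)cc2)cc1` gives 23.7% in this assay.
Compound 3 `CC1=C(C(=O)Nc2ccc([N+](=O)[O-])cc2)C(c2cccc([N+](=O)[O-])c2)N=C(SCc2cccc(Cl)c2)N1` gives 12.9% in this assay.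

Compound 3 stands lowest of the three, beyond the scatter from both compound 1 and compound 2. The change 4-chlorophenyl in place of 3-chlorophenyl on a saturated chain carbon bound to a sulfur made a step of a number 3.1 percentage points lower from compound 1 to compound 2 (within the scatter). The same change, (4-chlorophenyl in place of 3-chlorophenyl on a saturated chain carbon bound to a sulfur), leads from compound 3 to the unmeasured compound 4 `CC1=C(C(=O)Nc2ccc([N+](=O)[O-])cc2)C(c2cccc([N+](=O)[O-])c2)N=C(SCc2ccc(Cl)cc2)N1`. The difference between the core of compound 1 and the core of compound 3 is not broken down here. Because the measured step of a number 3.1 percentage points lower from compound 1 to compound 2 (within the scatter) stayed within the scatter, a step of similar size, a number 2.9 percentage points lower from compound 3 to compound 4 (within the scatter), is expected in this assay. For compound 4 the estimated value in this assay is 10%, with a likely range from 0% to 22%.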

Compound 4, a percentage reported as inhibition, in the whole organism at one dose (the size of the read-out at that dose, not a potency): 15.5%
The estimate for compound 4 lay 5.5 percentage points below the measured number, and the stated range covers the measured number.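

In this assay, moving the chlorine from 3-chlorobenzyl to 4-chlorobenzyl on the second core gave a step of a number 2.6 percentage points higher from compound 3 to compound 4 (within the scatter). The steps on the two cores can be set side by side: the same change on two cores in this assay, a number 3.1 percentage points lower (within the scatter) from compound 1 to compound 2 and a number 2.6 percentage points higher (within the scatter) from compound 3 to compound 4, 5.7 percentage points apart, within the scatter of two such steps. Going by these compounds alone, this shows that on these two cores the change made no step that stands out from the scatter, but it does not establish a shared direction for the change, nor does it show how the change would behave on any other core.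

The compounds shown leave open what a group other than chlorophenyl, such as an amine or a carboxylic acid, would give on the saturated chain carbon bound to a sulfur. They also leave open whether a longer chain in that place would give a number beyond the scatter.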